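The compounds below may be only part of what the source reports. "The series", "measured", "known", "first", "only" and "open" are said of these compounds alone.

Measured so far in a functional assay on the whole organism (artery, strain albino) with Rattus norvegicus as the target, with a stated time of 30 min, at a dose of 10 mg/kg by the oral route; on this read-out higher numbers stand for more inhibition at the one dose given (going by the name of the read-out) and lower numbers for less inhibition: compound 1 `CC1=C(C(=O)Nc2ccc(Br)cc2)C(c2ccc(Cl)cc2Cl)N=C(SCc2ccccc2Cl)N1` gives 5.7%; compound 2 `CC1=C(C(=O)Nc2ccc(Br)cc2)C(c2ccc(Cl)cc2Cl)N=C(SCc2cccc(Cl)c2)N1` gives 3.1%; compound 3 `COc1ccc(C2N=C(SCc3ccccc3Cl)NC(C)=C2C(=O)Nc2ccc(Br)cc2)cc1` gives 4.6%.

Compound 4 `COc1ccc(C2N=C(SCc3cccc(Cl)c3)NC(C)=C2C(=O)Nc2ccc(Br)cc2)cc1` has not yet been measured in this assay. For the measured compounds named here, it arises from compound 3 by the change (3-chlorophenyl in place of 2-chlorophenyl on a saturated chain carbon bound to a sulfur), which is the same change as the one from compound 1 to compound 2, (3-chlorophenyl in place of 2-chlorophenyl on a saturated chain carbon bound to a sulfur); that earlier step gave a number 2.6 percentage points lower from compound 1 to compound 2 (within the scatter). The two cores differ by 4-methoxyphenyl in place of 2,4-dichlorophenyl on a saturated ring carbon, and the step between them gave a number 1.1 percentage points lower from compound 1 to compound 3 (within the scatter). All three measured numbers sit close together, and neither step stands out from the usual scatter of this kind of measurement. For compound 4 a small step is therefore expected, about a number 2.1 percentage points lower from compound 3 to compound 4 (within the scatter), resting on the earlier step of a number 2.6 percentage points lower from compound 1 to compound 2 (within the scatter) from compound 1. Compound 4 is accordingly estimated at 2.5%, with a likely range from -6% to 11%.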

Compound 4, a percentage reported as inhibition, in the whole organism at one dose (the size of the read-out at that dose, not a potency): 7.7%
For compound 4 the middle estimate is 5.2 percentage points below the measured one, within the range that was stated.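

In this assay, 3-chlorophenyl in place of 2-chlorophenyl on a saturated chain carbon bound to a sulfur gives a number 3.1 percentage points higher from compound 3 to compound 4 (within the scatter), and this does not differ from the earlier step on the other core: the same change on two cores in this assay, a number 2.6 percentage points lower (within the scatter) from compound 1 to compound 2 and a number 3.1 percentage points higher (within the scatter) from compound 3 to compound 4, 5.7 percentage points apart, within the scatter of two such steps. The change of 4-methoxyphenyl in place of 2,4-dichlorophenyl on a saturated ring carbon gives a number 4.6 percentage points higher from compound 2 to compound 4 (within the scatter), and it agrees with its earlier step in the same way: the same change on two cores in this assay, a number 1.1 percentage points lower (within the scatter) from compound 1 to compound 3 and a number 4.6 percentage points higher (within the scatter) from compound 2 to compound 4, 5.7 percentage points apart, within the scatter of two such steps. Both changes are therefore compatible with carrying over from one core to the other, but with every step inside the scatter, this does not show that either change has a real effect at all.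

The compounds shown leave open whether any group at these two places can move the number clearly beyond the scatter. An amine or a carboxylic acid in place of the chlorophenyl on that chain carbon would be one such case.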